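The source may report more compounds than this note shows. Statements on the series, on what has been measured and on what is new or still open speak of the compounds shown alone.

Measured so far in a functional assay on CCRF-CEM cells (Homo sapiens) for cytotoxicity; on this read-out lower numbers stand for stronger inhibition and higher numbers for weaker inhibition:
compound 1 `COc1ccc(NC(=O)/C=C/C(=O)N2C/C(=C\c3ccc([N+](=O)[O-])cc3)C(=O)/C(=C/c3ccc([N+](=O)[O-])cc3)C2)cc1`: 760 nM
compound 3 `O=C(/C=C/C(=O)N1C/C(=C\c2ccc([N+](=O)[O-])cc2)C(=O)/C(=C/c2ccc([N+](=O)[O-])cc2)C1)Nc1ccc(Cl)c(Cl)c1`: 380 nM
compound 2 `O=C(/C=C/C(=O)N1C/C(=C\c2ccccc2)C(=O)/C(=C/c2ccccc2)C1)Nc1ccc([N+](=O)[O-])cc1`: 40000 nM

Compound 1 stands second highest of these three numbers. The nearest value is that of compound 3; the step of a 2.0-fold lower number from compound 1 to compound 3 (0.30 log units; within the scatter) is within the scatter. Among the compounds with values here, compound 2 lies far higher, beyond the scatter, but it differs from compound 1 in more than one place, so no single step links them.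

Compound 4 `O=C(/C=C/C(=O)N1C/C(=C\c2ccc([N+](=O)[O-])cc2)C(=O)/C(=C/c2ccc([N+](=O)[O-])cc2)C1)Nc1ccc([N+](=O)[O-])cc1` is still to be measured in this assay. It differs from compound 1 by nitro in place of methoxy on an aromatic carbon. Within the data shown here, the only measured step at the same position is the one from compound 1 to compound 3, which replaces the same methoxy with another group and leaves the number within the scatter. Compound 2 carries the same nitro-bearing anilide as compound 4 but also lacks the nitro groups of the shared core, so its value cannot be read as a step to compound 4.

The expected change from compound 1 to compound 4 is therefore a 1.6-fold higher number from compound 1 to compound 4 (0.20 log units; within the scatter), and no direction is claimed that would pass the scatter. The range is kept wide because compound 2 gives the weak number 40000 nM. The estimate for compound 4 is 1200 nM, range 350 nM to 5000 nM.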

Compound 4, half-maximal inhibitory concentration: 410 nM
Estimate against measurement, compound 4: 2.9-fold (0.47 log units) above; measured number inside the range.
By their numbers in this assay, from the lowest: compounds 3, 4 and 1 (each within the scatter of the next); then compound 2.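

In this assay the aryl group on the amide-type nitrogen of the shared core has now been varied beyond a single replacement: a 1.9-fold lower number from compound 1 to compound 4 (0.27 log units; within the scatter), and a 1.1-fold higher number from compound 3 to compound 4 (0.03 log units; within the scatter). Together with the earlier step, this places the 4-methoxyphenyl, 3,4-dichlorophenyl and 4-nitrophenyl compounds within the scatter of one another, so on this core none of the three can be separated from the others at this position. No measurement shown bears on why these numbers stay so close.

Still open, from the compounds shown here alone, is whether an amine or a carboxylic acid on the same aromatic carbon would give a step beyond the scatter. Also open, going by these compounds, is whether a longer alkyl chain in place of the whole aryl group on that nitrogen would do so.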